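Swapping Methyl for Chloro When Only Limits Exist

This account rests on a few compounds, and the source may have more. Where it says the series, first, only, none or still open, it means among the compounds named here.

In a functional assay on the whole organism for antagonist activity, with Mus musculus as the target (on this read-out lower numbers stand for an effect already at smaller amounts and higher numbers for an effect only at larger amounts of compound), compound 1 `CSc1nnc(-c2ccc(C)cc2)n1C` gives > 100 mg/kg, which is a limit and not a number. Compound 2 `Cc1ccc(-c2nnc([S+](C)[O-])n2C)cc1` gives > 200 mg/kg, also a limit. Compound 3 `Cc1ccc(-c2nnc(S(C)(=O)=O)n2C)cc1` gives > 200 mg/kg, again a limit.

Compound 4 `CSc1nnc(-c2ccc(Cl)cc2)n1C` differs from compound 1 as follows: chloro in place of methyl on an aromatic carbon.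

The nearest evidence is a step that the two limits leave unreadable from compound 1 to compound 2, together with a step that the two limits leave unreadable from compound 1 to compound 3 and a step that the two limits leave unreadable from compound 2 to compound 3. None of these steps has a readable size, and none replaces methyl with chloro, so they point in no direction. The expected change is therefore a number no higher from compound 1 to compound 4 (the limit leaves the size open), with no direction favoured. For compound 4 the estimate is 100 mg/kg, with an expected range from 30 mg/kg to 300 mg/kg.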

Compound 4, dose for half-maximal effect: > 200 mg/kg
Compound 4 gave a limit, no number; the forecaster's own chance of this, stated with the estimate: 50%; middle value at least 2.0-fold (0.30 log units) away from the limit.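

Compound 1 and compound 4 each gave only a limit and not a number, so the change from methyl to chloro has no readable size. The compounds shown leave open whether that change alters the dose needed for half-maximal effect.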